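Ethoxy-to-piperidinylmethyl swap on the biaryl ester series

The source may hold more compounds than are shown below. What is called first, only, known or untested is meant among the compounds shown, and "the series" means these compounds.

Measured so far in an assay on COS-7 cells for inhibition of patatin-like phospholipase domain-containing protein 2 (Mus musculus); a higher number here means a weaker inhibitor, a lower number a stronger inhibitor:
- compound 1 `CCOC(=O)c1cccc(-c2ccc(OCC)cc2)c1`: 50000 nM
- compound 2 `CCOC(=O)c1ccc(-c2ccc(OCC)cc2)o1`: 50000 nM
- compound 3 `CCOC(=O)c1cccc(-c2ccc(OCC)nc2)c1`: 130000 nM

Compound 1 and compound 2 sit level at the digits given, and together they hold the lowest numbers of the three; the gap between them is within the scatter, so no order can be read from it. Compound 3 stands furthest from compound 1, with a higher number that lies beyond the scatter.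

The next compound, compound 4 `CCOC(=O)c1cccc(-c2ccc(CN3CCCCC3)cc2)c1`, departs from compound 1 by one change: (piperidin-1-yl)methyl in place of ethoxy on an aromatic carbon. Among the measured compounds shown here, no measured pair in the set shares this change, so there is no step on record to lean on; the only guide is that every measured compound so far lies in the same weak range, and that the one change on record that did move the number, from compound 1 to compound 3, moved it upward.

With nothing to anchor the direction, the expectation for compound 4 in this assay is a step of a 1.1-fold lower number from compound 1 to compound 4 (0.05 log units; within the scatter), that is, no change beyond the scatter, with wide uncertainty either way. Compound 4 is therefore estimated at 45000 nM, in a range from 8000 nM to 200000 nM.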

Compound 4, half-maximal inhibitory concentration: 75000 nM
The estimate for compound 4 lay 1.7-fold (0.22 log units) below the measured number; low and high end bracket the measured number.
By their numbers in this assay, from the lowest: compounds 1, 2, 4 and 3 (each within the scatter of the next, the first and the last beyond it).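

In this assay, among the compounds shown here, (piperidin-1-yl)methyl in place of ethoxy on an aromatic carbon, para to a large group, gives a 1.5-fold higher number from compound 1 to compound 4 (0.18 log units; within the scatter) and is the first step on record at this position. The position therefore takes a group with one six-membered non-aromatic ring in place of an open chain with no ring, and the number shows no change beyond the scatter. In this one pair, the added ring and the exchange of the ether oxygen for a ring nitrogen neither gain nor lose anything that can be read, and nothing on hand explains why the number holds across this swap.

Still open, as far as these compounds go, is whether another group at this position, such as morpholin-4-ylmethyl, dimethylaminomethyl or a carboxylic acid, would move the number beyond the scatter, which would show whether this position can change the read-out at all. Also open, from the compounds shown here alone, is whether (piperidin-1-yl)methyl in place of ethoxy gives a similar step on the core of compound 2 or of compound 3, since this change stands on a single pair.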